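The compounds below may be only part of what the source reports. "The series", "measured", "known", "first", "only" and "open" are said of these compounds alone.

Values in an ADME assay on HEK293 cells (Homo sapiens) for cytotoxicity, read by resazurin assay, with a stated time of 48 h (a higher number here means that more compound is tolerated, a lower number that less compound is tolerated), for the three measured compounds:

Compound 1 `O=C(Nc1ccc(Sc2nc3ccccc3s2)c(Cl)c1)c1cccc(Br)c1O` gives 68000 nM.
Compound 2 `COc1ccc(S(=O)(=O)Nc2ccc3oc(-c4ccc(NS(=O)(=O)c5cc(F)ccc5OC)cc4)nc3c2)cc1` gives 24000 nM.
Compound 3 `O=S(=O)(Nc1ccc(-c2nc3cc(NS(=O)(=O)c4ccccc4)ccc3o2)cc1)c1ccccc1` gives 25000 nM.

Compound 2 has the lowest number of the three. Compound 3 lies closest to it, and the gap between compound 2 and compound 3 is within the usual scatter, so no order between those two is claimed. Compound 1 stands furthest from compound 2, with a higher number beyond the scatter.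

The unmeasured compound 4 `COc1ccc(S(=O)(=O)Nc2ccc3oc(-c4ccc(NC(=O)c5ccc(Cl)s5)cc4)nc3c2)cc1` is derived from compound 2 by one change: a group of 8 heavy atoms (5 carbon, 1 oxygen, 1 sulfur, 1 chlorine; one five-membered aromatic ring with 1 hetero atom) in place of a group of 12 heavy atoms (7 carbon, 3 oxygen, 1 fluorine, 1 sulfur; one six-membered aromatic ring of carbon only), on a nitrogen on an aromatic ring. The pair keeps everything else unchanged.

For the measured compounds named here, no pair of measured compounds differing in a single place is available, so the size of this kind of step cannot be read from the series. With compound 2 at 24000 nM and compound 3, carrying a related change elsewhere, at 25000 nM, the expectation is a step in this assay of no more than the scatter, in no fixed direction. The estimated step from compound 2 to compound 4 is a 1.0-fold higher number from compound 2 to compound 4 (0.02 log units; within the scatter). For compound 4 the expected value is 25000 nM, with a range from 10000 nM to 60000 nM.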

Compound 4, half-maximal cytotoxic concentration: 15000 nM
Beside the measured number, compound 4's estimate is 1.7-fold (0.22 log units) above it, within the range that was stated.
By their numbers in this assay, from the lowest: compounds 4, 2 and 3 (each within the scatter of the next); then compound 1.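

In this assay, the series now has its first step in a single place: a 1.6-fold lower number from compound 2 to compound 4 (0.20 log units; within the scatter). On a nitrogen on an aromatic ring whose other neighbours are aromatic carbon, (5-chlorothiophen-2-yl)carbonyl with its five-membered aromatic ring can therefore replace the group with a six-membered aromatic ring of carbon only, and the difference stays within the scatter of the measurement. No measured property of either group bears on this result, so the step has no stated cause.

This single step does not show whether the same holds for the thiophene without its chlorine or for a small acetyl group on this nitrogen. It also leaves open whether a free amine here, or a chain ending in a carboxylic acid, would stay as close to compound 2.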